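The compounds below may be only part of what the source reports. "The series", "measured", "known", "first", "only" and "open" are said of these compounds alone.

Working notes on the series in an ADME assay on PBMC cells (Homo sapiens) for cytotoxicity; a lower number here means that less compound is tolerated, a higher number that more compound is tolerated.

Three compounds in the series carry a number here. Compound 1 `Cc1cccnc1OC(c1ccc(C(F)(F)F)cc1)C1CCN(C(C)CCNC(=O)c2c(Cl)cncc2Cl)CC1` gives 33000 nM, the lowest of the three. Compound 3 `CC(CCNC(=O)c1c(Cl)cncc1Cl)N1CCC(C(Oc2ccccn2)c2ccc(Br)cc2)CC1` gives 33700 nM, and this sits within the usual scatter of the number for compound 1, so the two are not to be ordered against each other. Compound 2 `CCO/N=C(/c1ccc(Br)cc1)C1CCN(C(C)CNC(=O)c2c(C)cc[n+]([O-])c2C)CC1` gives 182000 nM, which lies beyond the scatter on the higher side. Among the measured compounds shown here, no pair among the measured compounds differs in only one place, so no single structural step has a measured size attached to it, and the spread between compound 1 and compound 2 involves several changes at once.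

Compound 4 `COC(=O)c1cccc(OC(c2ccc(C(F)(F)F)cc2)C2CCN(C(C)CCNC(=O)c3c(Cl)cncc3Cl)CC2)c1` has not yet been run. It differs from compound 1 in one place: 3-(methoxycarbonyl)phenyl in place of 3-methylpyridin-2-yl on an oxygen on a saturated carbon. For the measured compounds named here, nothing among the measured compounds covers this particular change, so its weight is unknown; the two closest analogues, compound 1 and compound 3, sit together, which gives no pull in either direction. The step from compound 1 to compound 4 is therefore expected to be small, with no preferred direction, most likely not beyond the scatter, no change at the digits printed from compound 1 to compound 4 (within the scatter). For compound 4 the estimate is 33000 nM, with a range from 11000 nM to 100000 nM.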

Compound 4, half-maximal cytotoxic concentration: 15200 nM
For compound 4 the middle estimate is 2.2-fold (0.34 log units) above the measured one; measured number inside the range.
By their numbers in this assay, from the lowest: compound 4; then compounds 1 and 3 (each within the scatter of the next); then compound 2.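

Among the compounds shown here, this is the first single-place step with a measured size. In this assay, 3-(methoxycarbonyl)phenyl in place of 3-methylpyridin-2-yl on an oxygen on a saturated carbon gives a 2.2-fold lower number from compound 1 to compound 4 (0.34 log units; beyond the scatter), so a change at this position can move the number beyond the scatter, though the step is modest. The change alters several counted features together, replacing a ring with a hetero atom by a ring of carbon only and adding heavy atoms, a double bond outside aromatic rings and a hydrogen-bond acceptor, and no measurement available here bears on which of these accounts for the lower number.

Open, on these data alone, is whether the lower number follows the methoxycarbonyl group or the loss of the ring nitrogen: an unsubstituted phenyl on the same oxygen would separate these two readings, and a carboxylic acid in place of the methoxycarbonyl group would test the group further. Also open, as far as these compounds go, is whether the same step would be of similar size on the core of compound 3.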